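The source may hold more compounds than are shown below. What is called first, only, known or untested is meant among the compounds shown, and "the series" means these compounds.

Measured compounds in an assay on DDT1 cells (Cricetulus griseus) for binding affinity to adenosine receptor A1 (Homo sapiens), read by radioligand binding; a higher number here means a weaker inhibitor, a lower number a stronger inhibitor:
compound 1 `CNC(=O)OC[C@H]1OC(n2cnc3c(NC4CCOC4)nc(Cl)nc32)[C@H](O)[C@@H]1O` — compound 1 gives 96 nM
compound 2 `CCCCNC(=O)OC[C@H]1OC(n2cnc3c(NC4CCOC4)ncnc32)[C@H](O)[C@@H]1O` — compound 2 gives 1410 nM
compound 3 `CCCC/N=C(\S)OC[C@H]1OC(n2cnc3c(NC4CCOC4)ncnc32)[C@H](O)[C@@H]1O` — compound 3 gives 157 nM

Compound 3 and compound 1 lie within the scatter of each other, so no order between the two is claimed. Against compound 2 the gap is real: a 9.0-fold lower number from compound 2 to compound 3 (0.95 log units; beyond the scatter), and this is the only single-place step among the measured compounds. Within the data shown here, compound 1 and compound 2 differ in two places at once, so that pair yields no clean step.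

Compound 4 `O[C@@H]1[C@@H](CO/C(S)=N/C2CCC2)OC(n2cnc3c(NC4CCOC4)ncnc32)[C@@H]1O` is the next member, not yet measured in this assay. It arises from compound 3 by cyclobutyl in place of butyl on a double-bonded nitrogen. Among the measured compounds shown here, no measured step addresses an exchange of this kind: the one step in hand swaps an oxygen for a sulfur and leaves the butyl untouched, and the remaining pair is confounded by a second change on the core. With nothing pointing either way, the working expectation is a number close to that of compound 3, within the scatter, so the step assumed is a 1.0-fold higher number from compound 3 to compound 4 (0.01 log units; within the scatter). For the measured compounds named here, compound 4 is therefore estimated at 160 nM, with a range from 60 nM to 450 nM that is kept wide because no directly comparable step exists.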

Compound 4, inhibition constant: 148 nM
Estimate against measurement, compound 4: 1.1-fold (0.03 log units) above; low and high end bracket the measured number.
By their numbers in this assay, from the lowest: compounds 1, 4 and 3 (each within the scatter of the next); then compound 2.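

In this assay, among these compounds, cyclobutyl in place of butyl on a double-bonded nitrogen gives a 1.1-fold lower number from compound 3 to compound 4 (0.03 log units; within the scatter), so this position accepts a four-membered ring of carbon only with no change beyond the scatter, whereas the earlier compounds showed only the open butyl chain there. The separation from the oxygen-containing group of the earlier series also holds with the ring in place, with a 9.5-fold lower number from compound 2 to compound 4 (0.98 log units; beyond the scatter) standing alongside a 9.0-fold lower number from compound 2 to compound 3 (0.95 log units; beyond the scatter), so the sulfur-containing group is now seen with two different groups on the nitrogen and both steps lie beyond the scatter. No supporting data bear on why either exchange gives these numbers.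

Still open, on these data alone, is whether the flat response at this nitrogen extends to a larger ring such as cyclopentyl, to a phenyl group or to a longer chain such as hexyl, since butyl and cyclobutyl have the same count of carbon atoms. Also open is what the chlorine on the core of compound 1 contributes on its own, as no single-place step isolates it in the compounds shown.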